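Swapping an aryl ketone for a cyclopropyl ketone

The compounds below may be only part of what the source reports. "The series", "measured", "known", "first", "only" and "open" are said of these compounds alone.

Of the compounds shown here, three sharing one core have been tested in a functional assay on A549 cells (Homo sapiens) for cytotoxicity, read by MTT assay, with a stated time of 48 h; on this read-out lower numbers stand for stronger inhibition and higher numbers for weaker inhibition. Compound 1 `COc1cc(C(=O)C2Sc3nnc(-c4cc(OC)c(OC)c(OC)c4)n3NC2c2ccco2)cc(OC)c1OC` gives 48300 nM. Compound 2 `COc1cc(-c2nnc3n2NC(c2ccco2)C(C(=O)c2ccc(Br)cc2)S3)cc(OC)c1OC`, which carries a 4-bromophenyl on the carbonyl carbon, gives 42100 nM. Compound 3 `COc1cc(-c2nnc3n2NC(c2ccco2)C(C(=O)c2ccc(F)cc2)S3)cc(OC)c1OC`, with a 4-fluorophenyl on that carbonyl carbon, gives 53700 nM. The three numbers sit close together: the step of a 1.1-fold lower number from compound 1 to compound 2 (0.06 log units; within the scatter), the step of a 1.1-fold higher number from compound 1 to compound 3 (0.05 log units; within the scatter) and the step of a 1.3-fold higher number from compound 2 to compound 3 (0.11 log units; within the scatter) all stay within the scatter, so none of these three aryl groups on the carbonyl carbon can be told apart on this read-out.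

Compound 4 `COc1cc(-c2nnc3n2NC(c2ccco2)C(C(=O)C2CC2)S3)cc(OC)c1OC` has not yet been measured. The change is cyclopropyl in place of 4-fluorophenyl on a carbonyl carbon. For the measured compounds named here, none of the measured steps covers this kind of change; all three only exchange one six-membered aromatic ring for another on the carbonyl carbon, and each of those exchanges left this assay unmoved. A three-membered ring in place of an aromatic ring goes further than anything measured, so the expectation rests on the flat pattern alone and carries a wide range. Compound 4 is estimated to give 60000 nM, with a likely range from 25000 nM to 150000 nM, meaning an expected step of a 1.1-fold higher number from compound 3 to compound 4 (0.05 log units; within the scatter) that may well stay within the scatter.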

Compound 4, half-maximal inhibitory concentration: > 100000 nM
Compound 4 gave a limit, no number (the forecaster's own chance of this, stated with the estimate: 20%); at least 1.6-fold (0.22 log units) between middle value and limit.
By their numbers in this assay, from the lowest: compounds 2, 1 and 3 (each within the scatter of the next). At a limit, above all of these: compound 4.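

In this assay compound 4 returns a limit rather than a number: the limit of > 100000 nM in this assay, at which 1 of the 4 values shown sits.

That limit is not a number. The steps can be read only as floors: an at least 2.3-fold higher number from compound 2 to compound 4 (0.37 log units; beyond the scatter) and an at least 2.0-fold higher number from compound 1 to compound 4 (0.31 log units; beyond the scatter) are beyond the scatter, whereas the floor of an at least 1.8-fold higher number from compound 3 to compound 4 (0.27 log units; that floor lies within the scatter) is not. Cyclopropyl on this carbonyl carbon is therefore the first change shown to move the read-out beyond the scatter, so the position is not indifferent to every group, although the comparison with compound 3 does not by itself establish this.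

The compounds shown leave open whether the loss follows from removing the aromatic ring or from going to a smaller ring, and a cyclohexyl ketone, with a six-membered non-aromatic ring, would help separate those two readings. They also leave open whether any group on this carbonyl carbon can bring the number well below those of compounds 1, 2 and 3, for instance a phenyl ring carrying an amine or a carboxylic acid.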